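The compounds below may be only part of what the source reports. "The series", "measured", "known", "first", "only" and "open" are said of these compounds alone.

Compound 3 `Cc1ccc(CSc2n[nH]c(-n3[se]c4ccccc4c3=O)n2)cc1` gives 34800 nM in a functional assay on HeLa cells (Homo sapiens) for antiproliferative activity, read by CCK-8 assay, with a stated time of 48 h; on this read-out higher numbers stand for weaker inhibition and lower numbers for stronger inhibition. Compound 2 `CCCCCCSc1n[nH]c(-n2[se]c3ccccc3c2=O)n1` gives 35900 nM in this assay, so the two sit at the same level: a 1.0-fold lower number from compound 2 to compound 3 (0.01 log units; within the scatter). Compound 1 `O=c1c2ccccc2[se]n1-c1nc(SCc2ccccc2)n[nH]1` reaches only a limit of the assay in this assay, > 50000 nM. The steps from compound 1 are bounded by that limit of > 50000 nM in this assay, at which 1 of the 3 values shown sits, and read as an at least 1.3-fold lower number from compound 1 to compound 2 (0.14 log units; that floor lies within the scatter) and an at least 1.4-fold lower number from compound 1 to compound 3 (0.15 log units; that floor lies within the scatter); neither floor rises out of the scatter.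

Compound 4 `Cc1cccc(CSc2n[nH]c(-n3[se]c4ccccc4c3=O)n2)c1` differs from compound 3 by 3-methylphenyl in place of 4-methylphenyl on a saturated chain carbon bound to a sulfur. The step that bears most directly on it is a 1.0-fold lower number from compound 2 to compound 3 (0.01 log units; within the scatter), where exchanging a pentyl for a 4-methylphenyl on the saturated chain carbon bound to the sulfur left the number unchanged. The other step touching the benzyl part, an at least 1.4-fold lower number from compound 1 to compound 3 (0.15 log units; that floor lies within the scatter), adds a methyl on an aromatic carbon and is bounded by a limit whose floor lies within the scatter. Exchanging 4-methylphenyl for 3-methylphenyl is a smaller change than either, so no step beyond the scatter is expected: a 1.0-fold higher number from compound 3 to compound 4 (0.00 log units; within the scatter). Compound 4 is therefore estimated to give 35000 nM in this assay, with an expected range from 17000 nM to 70000 nM.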

Compound 4, half-maximal inhibitory concentration: 42600 nM
Estimate against measurement, compound 4: 1.2-fold (0.09 log units) below, and the stated range covers the measured number.
By their numbers in this assay, from the lowest: compounds 3, 2 and 4 (each within the scatter of the next). At a limit, above all of these: compound 1.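

Exchanging 4-methylphenyl for 3-methylphenyl on the saturated chain carbon bound to a sulfur gives a 1.2-fold higher number from compound 3 to compound 4 (0.09 log units; within the scatter) in this assay, so this first comparison of two methylphenyl groups at this place shows no separation between them. The 3-methylphenyl also stands level with the pentyl, a 1.2-fold higher number from compound 2 to compound 4 (0.07 log units; within the scatter), which adds a second aromatic group to the pentyl at one level, with no order among compounds 2, 3 and 4. The step that adds a methyl on an aromatic carbon starts from a limit of the assay and reads only as a floor, an at least 1.1-fold lower number from compound 1 to compound 4 (0.06 log units; that floor lies within the scatter), so it does not show any effect of that methyl: the limit of > 50000 nM in this assay, at which 1 of the 4 values shown sits.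

The compounds shown leave open whether a group other than methyl on the phenyl ring, such as an amine, a carboxylic acid or a methoxy, or a chain longer than the pentyl, would move the number out of this level. Also open, going by these compounds, is whether a change on the shared core, rather than on the group at this place, would do so.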